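The compounds below may be only part of what the source reports. "The series", "measured", "known", "first", "only" and "open" are said of these compounds alone.

Measured so far in a physicochemical assay for solubility, in phosphate buffer, measured as kinetic solubility, with a stated time of 1 h, at pH 7.4; a lower number here means a less soluble compound, a higher number a more soluble compound:
compound 1, `Cc1cc(C)cc(NC(=O)COc2cc(C)nc3ccc(F)cc23)c1`, with 28000 nM
compound 2, `CCC(Oc1cc(C)nc2ccc(OC)cc12)C(=O)Nc1cc(C)cc(C)c1`, with 123000 nM
compound 3, `COc1ccc2nc(C)cc(OCC(=O)Nc3cc(F)cc(F)c3)c2c1`, with 13000 nM

Compound 3 stands lowest of the three numbers in this assay. Compound 1 is its nearest neighbour, with a number above that of compound 3 by more than the scatter; compound 2 lies furthest away, also above by more than the scatter. Going by the values given here, none of the three pairs differs in only one place, so the series offers no measured single step to lean on, and whatever is expected for the next compound rests on the structural change alone.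

Compound 4, `COc1ccc2nc(C)cc(OCC(=O)NNC(=O)c3ccncc3)c2c1`, is the one not yet measured. It differs from compound 3 in one place: ((pyridin-4-yl)carbonyl)amino in place of 3,5-difluorophenyl on an amide-type nitrogen. An aromatic ring of carbon only gives way to one with a hetero atom, joined through a carbonyl-bearing linkage rather than directly, and the group that enters brings donor and acceptor capacity that the group that leaves does not have.

In this assay a step up from compound 3 to compound 4 is expected, of about a 5.0-fold higher number from compound 3 to compound 4 (0.70 log units; beyond the scatter), clearly beyond the scatter. The estimate for compound 4 is therefore 65000 nM, with a range from 20000 nM to 200000 nM.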

Compound 4, solubility: >= 375000 nM
Compound 4: a limit, no number; the forecaster's own chance of this, stated with the estimate: 5%; middle value at least 5.7-fold (0.76 log units) from the limit.
By their numbers in this assay, from the lowest: compound 3; then compound 1; then compound 2. At a limit, above all of these: compound 4.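

In this assay compound 4 gives >= 375000 nM, which is a limit of the assay and not a number. Going by these compounds alone, the replacement of 3,5-difluorophenyl by ((pyridin-4-yl)carbonyl)amino on an amide-type nitrogen is the only single change that can be read, and it gives an at least 28-fold higher number from compound 3 to compound 4 (1.46 log units; beyond the scatter), a large step that the earlier compounds, with no single change among them, could not show for this place. The step therefore fixes a direction and a minimum size, while its full size stays unknown: the limit of >= 375000 nM in this assay, at which 1 of the 4 values shown sits.

Going by these compounds, the change brings in a ring with a hetero atom, a carbonyl-bearing linkage, and 1 hydrogen-bond donor and 2 hydrogen-bond acceptors all at once, so it remains open what a benzoylamino group, with a carbon-only ring on the same linkage, or a pyridin-4-yl ring joined directly to the amide-type nitrogen would give in this assay. Also open, on these data alone, is whether ((pyridin-4-yl)carbonyl)amino gives a step of similar size on the other parts of compound 1 or compound 2.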